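This account rests on a few compounds, and the source may have more. Where it says the series, first, only, none or still open, it means among the compounds named here.

The measured compounds:
Compound 1, `COc1ccc(OC)c(S(=O)(=O)NC(=O)c2ccc(Cn3ccc4ccc(NC(=O)CC5CCCC5)cc43)c(OC)c2)c1`, in a functional assay (trachea) for antagonist activity, with Cavia porcellus as the target (a lower number here means a less potent compound, a higher number a more potent compound, by a factor of ten per unit of this negative logarithm), gives 9.1.
Compound 2, `COc1cc(C(=O)NS(=O)(=O)c2ccccc2OC)ccc1Cn1ccc2ccc(NC(=O)CC3CCCC3)cc21`, in this assay gives 9.7.
Compound 3, `CCCCC(CC)C(=O)Nc1ccc2ccn(Cc3ccc(C(=O)NS(=O)(=O)c4ccccc4)cc3OC)c2c1`, in this assay gives 8.6.

From compound 1 to compound 2 the change is hydrogen in place of methoxy on an aromatic carbon, and this gave a number 0.60 log units higher from compound 1 to compound 2 (beyond the scatter). Compound 3 has the lowest of the three numbers in this assay; the difference between its core and the core of compound 1 is not broken down here. Compound 4, `CCCCC(CC)C(=O)Nc1ccc2ccn(Cc3ccc(C(=O)NS(=O)(=O)c4ccccc4)cc3)c2c1`, is not yet measured. It differs from compound 3 by hydrogen in place of methoxy on an aromatic carbon. Within the data shown here, this is the same kind of change as the one from compound 1 to compound 2, but the place is not the same: in compound 1 the leaving group sits meta to a large group and para to a methoxy group, whereas in compound 3 it sits ortho to a large group and meta to a (phenylsulfonyl)carbamoyl group. The expected step from compound 3 to compound 4 is a number 0.20 log units lower from compound 3 to compound 4 (within the scatter), smaller than the earlier one, because a number 0.60 log units higher from compound 1 to compound 2 (beyond the scatter) came from a methoxy in a different place and says little about this one. Compound 4 is therefore estimated at 8.4 in this assay, with the likely range running from 7.6 to 9.2.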

Compound 4, negative logarithm of the antagonist equilibrium constant: 6.8
Estimate against measurement, compound 4: 1.60 log units above, outside the stated range (below it).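

Replacing the methoxy ortho to a large group with hydrogen gave, in this assay, a number 1.80 log units lower from compound 3 to compound 4 (beyond the scatter), so on this core the methoxy counts for a great deal. Set beside the earlier step, the same written change does not carry from one core to another in this series, in either direction or size: the same change on two cores in this assay, a number 0.60 log units higher (beyond the scatter) from compound 1 to compound 2 and a number 1.80 log units lower (beyond the scatter) from compound 3 to compound 4, 2.40 log units apart, beyond the scatter of two such steps. This does not show why the two steps part, since the methoxy sits in a different place in each pair and the cores differ too, so these two pairs cannot separate the effect of place from that of core.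

The compounds shown leave open what the same methoxy-to-hydrogen change would do at this place on the core of compound 2, which would test place and core apart. They also leave open whether a different group there, such as a fluorine, a hydroxyl or an ethoxy, would hold the number of compound 3 or fall towards that of compound 4.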